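The source may hold more compounds than are shown below. What is called first, only, known or untested is meant among the compounds shown, and "the series" means these compounds.

Measured in a functional assay on HepG2 cells (Homo sapiens) for antiproliferative activity, read by MTT assay, with a stated time of 48 h; on this read-out lower numbers stand for stronger inhibition and higher numbers for weaker inhibition:
Compound 1 `O=C(CN1CCCC1)Nc1ccc2ncnc(Nc3ccc(Cl)cc3)c2c1`: 18000 nM
Compound 2 `O=C(CN1CCCC1)Nc1ccc2ncnc(Nc3ccc(Br)cc3)c2c1`: > 100000 nM (a limit of the assay, not a number)

Compound 2 sits at the limit of > 100000 nM in this assay, at which 1 of the 2 values shown sits, so it has only a limit and no number. Compound 3 `O=C(CN1CCCC1)Nc1ccc2ncnc(Nc3ccc(OCc4ccccc4)cc3)c2c1` differs from compound 2 in one place: benzyloxy in place of bromo on an aromatic carbon. Benzyloxy stands in place of bromo on an aromatic carbon, para to a large group. Going by the values given here, the only measured step that bears on this position is an at least 5.5-fold higher number from compound 1 to compound 2 (0.74 log units; beyond the scatter), with bromo in place of chloro. That step shows that this position matters in this assay, but it covers a far smaller exchange and gives only a loose guide. A measurable result for compound 3 can lie only on the lower-number side of that limit, though compound 3 may also stop at the limit. The expected change is an at least 2.8-fold lower number from compound 2 to compound 3 (0.45 log units; beyond the scatter), toward stronger inhibition. For compound 3 the estimated value is 35000 nM, with an expected range from 8000 nM to 100000 nM.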

Compound 3, half-maximal inhibitory concentration: > 100000 nM
Compound 3 was reported as a limit (the forecaster's own chance of this, stated with the estimate: 35%); middle value at least 2.8-fold (0.45 log units) away from the limit.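

In this assay, benzyloxy in place of chloro gives an at least 5.5-fold higher number from compound 1 to compound 3 (0.74 log units; beyond the scatter), so a second exchange at this position, and a much bigger one, also moves away from compound 1, which alone among the compounds shown has a measured number. Compound 3 has only a limit of the assay, > 100000 nM, not a number. The step between compound 2 and compound 3 cannot be read, so bromo and benzyloxy cannot be ordered, and both end at the same ceiling: the limit of > 100000 nM in this assay, at which 2 of the 3 values shown sit.

Going by these compounds, it remains open whether a fluoro, a methoxy or an amine at this position would give a measurable number, and whether any of them would match or pass chloro. On these data alone, how far compound 2 and compound 3 lie beyond their limits also stays unknown.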